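The compounds below may be only part of what the source reports. "The series", "measured", "known", "first", "only" and "open" are said of these compounds alone.

Working notes on the series in a functional assay on CHO cells for agonist activity at adenosine receptor A1 (Homo sapiens), read by fluorescence and ERK phosphorylation, with stated times of 30 min and 1.5 h, tested at 10 uM; a higher number here means a stronger effect of the compound at the concentration tested, a lower number a weaker effect. Compound 1 `Nc1scc(-c2ccccc2F)c1C(=O)c1ccccc1` gives 68% in this assay. Compound 2 `Nc1scc(-c2cccc(F)c2)c1C(=O)c1ccccc1` carries 3-fluorophenyl in place of 2-fluorophenyl on an aromatic carbon; in this assay compound 2 gives 52%, a step of a number 16 percentage points lower from compound 1 to compound 2 (beyond the scatter). Compound 3 `Nc1scc(-c2ccccc2F)c1C(=O)c1ccc(Cl)cc1` differs from compound 1 by chloro in place of hydrogen on an aromatic carbon, and in this assay compound 3 gives 87%, a step of a number 19 percentage points higher from compound 1 to compound 3 (beyond the scatter). Compound 4 `Nc1scc(-c2cccc(F)c2)c1C(=O)c1ccc(Cl)cc1` is not yet measured; it differs from compound 3 by 3-fluorophenyl in place of 2-fluorophenyl on an aromatic carbon, the same kind of change as from compound 1 to compound 2, though here the place is next to the ring atom that bears a group of 9 heavy atoms rather than 8. The expected step is a number 16 percentage points lower from compound 3 to compound 4 (beyond the scatter), resting on a number 16 percentage points lower from compound 1 to compound 2 (beyond the scatter) seen on the core of compound 1; nothing shown suggests the two cores respond differently. Compound 4 is therefore estimated at 71%, within 55% to 85%.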

Compound 4, a percentage reported as activity, at one concentration (the size of the read-out at that concentration, not a potency): 90%
Beside the measured number, compound 4's estimate is 19 percentage points below it, outside the stated range (above it).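

On the core of compound 3, 3-fluorophenyl in place of 2-fluorophenyl gives a number 3 percentage points higher from compound 3 to compound 4 (within the scatter), so in this assay this change did not carry over unchanged from the core of compound 1: the same change on two cores in this assay, a number 16 percentage points lower (beyond the scatter) from compound 1 to compound 2 and a number 3 percentage points higher (within the scatter) from compound 3 to compound 4, 19 percentage points apart, beyond the scatter of two such steps. Chloro in place of hydrogen gives a number 38 percentage points higher from compound 2 to compound 4 (beyond the scatter), and the size of that step also depends on the core: the same change on two cores in this assay, a number 19 percentage points higher (beyond the scatter) from compound 1 to compound 3 and a number 38 percentage points higher (beyond the scatter) from compound 2 to compound 4, 19 percentage points apart, beyond the scatter of two such steps. Across these four compounds the two changes therefore do not add independently, but the data do not show why, or whether this holds for any other compound.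

On these data alone, whether bromo or methoxy in place of the chloro, or unsubstituted phenyl in place of the fluorophenyl, would show the same dependence remains open. As far as these compounds go, each read-out gives the stronger or weaker effect at a single concentration only, and how the compounds compare at any other concentration remains open.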